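A cyanophenyl substitute for the styryl chain

A few compounds are considered here, and "the series" means these few. Any claim that something is new, unique, unknown or untested is made for them only; others in the source may bear on it.

Compound 1, `Nc1nc(O)c2c(n1)n(C1OC(CO)[C@@H](O)[C@H]1O)c(=O)n2C/C=C/c1ccccc1`, sets the reference point in a functional assay on the whole organism (B cells) with Mus musculus as the target (a higher number here means a larger maximal response, a lower number a smaller maximal response), where compound 1 reaches 73%. For the measured compounds named here, the only other compound measured, compound 2, `C=CCn1c(=O)n(C2CCC(CO)C2)c2nc(N)nc(O)c21`, reaches 26% in this assay, a value well below that of compound 1 and beyond the usual scatter, so compound 1 holds the higher of the two numbers. Going by the values given here, no pair of measured compounds differs in one place alone, so no single structural step can be read from the measured data.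

Compound 3, `N#Cc1cccc(Cn2c(=O)n(C3OC(CO)[C@@H](O)[C@H]3O)c3nc(N)nc(O)c32)c1`, has not been measured. It differs from compound 1 in one place: 3-cyanophenyl in place of 2-phenylethenyl on a saturated chain carbon bound to an aromatic nitrogen. The 2-phenylethenyl group leaves and 3-cyanophenyl enters, on the saturated chain carbon bound to an aromatic nitrogen; one double bond outside aromatic rings is exchanged for one triple bond, and one hydrogen-bond acceptor is gained. Among the compounds with values here, nothing among the measured compounds shows this exchange, so its effect can only be guessed. The expected step in this assay is a number 18 percentage points lower from compound 1 to compound 3 (beyond the scatter), a moderate decrease. The estimate for compound 3 in this assay is 55%, within 30% to 85%.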

Compound 3, largest response reached (reported as maximal response), in percent of the reference or control that the assay uses: 16%
Estimate against measurement, compound 3: 39 percentage points above; the measured number lies below the stated range.
By their numbers in this assay, from the lowest: compounds 3 and 2 (each within the scatter of the next); then compound 1.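

In this assay, for the compounds shown here, the exchange of 2-phenylethenyl for 3-cyanophenyl on the saturated chain carbon bound to an aromatic nitrogen brings a number 57 percentage points lower from compound 1 to compound 3 (beyond the scatter) and gives the first readable step at this position. The maximal response therefore depends strongly on what is attached at this place, even though both groups have the same number of heavy atoms and each holds one six-membered aromatic ring of carbon only. No measurement at hand explains this drop.

The step removes the double bond and introduces the nitrile together, so the compounds shown leave open which of the two changes accounts for the difference; a plain benzyl group or a saturated 3-phenylpropyl chain in the same place would help to separate them. Also open, going by these compounds, is whether the response depends on the nitrile itself or would change in the same way with another group on the benzyl ring, such as a methoxy group, an amine or a carboxylic acid.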